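Swapping the amide-ring aryl group toward a simpler chloro-substituted ring

This account rests on a few compounds, and the source may have more. Where it says the series, first, only, none or still open, it means among the compounds named here.

Measured compounds:
- compound 1 `Cc1cccc(-c2noc(C3CC(=O)N(c4ccc(C)c(Cl)c4)C3)n2)c1`: 240 nM
- compound 2 `Cc1ccc(N2CC(c3nc(-c4cccc(C(F)(F)F)c4)no3)CC2=O)cc1`: 3400 nM
- compound 3 `Cc1ccc(N2CC(c3nc(-c4cccc(Cl)c4)no3)CC2=O)cc1C`: 310 nM

Of the compounds shown here, three sharing one core have been tested in an in vitro functional assay on HEK293-A cells for positive allosteric modulation of metabotropic glutamate receptor 5 (Homo sapiens), read by FLIPR and calcium flux; a higher number here means that more compound is needed for the effect, a lower number that less compound is needed. Compound 1 gives 240 nM and sits at the lowest number of the three, though its gap to compound 3, which gives 310 nM, lies within the scatter, so no order between those two can be claimed. Compound 2 gives 3400 nM in this assay, and its gap from compound 1 lies beyond the scatter.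

The unmeasured compound 4 `Cc1cccc(-c2noc(C3CC(=O)N(c4ccc(Cl)cc4)C3)n2)c1` differs from compound 1 in a single place: 4-chlorophenyl in place of 3-chloro-4-methylphenyl on an amide-type nitrogen in a ring. Within the aryl group on that ring nitrogen, a methyl is lost and the chlorine appears at the 4-position of the ring rather than the 3-position, with the rest of the molecule untouched. Among the measured compounds shown here, no pair of measured compounds isolates this change, so the expectation can rest only on the spread of values seen so far. Compound 4 is expected to give a somewhat higher number, since reducing substitution on this aryl group is estimated to cost a modest step of a 2.5-fold higher number from compound 1 to compound 4 (0.40 log units; beyond the scatter). Compound 4 is therefore estimated at 600 nM, within a range from 200 nM to 2500 nM.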

Compound 4, half-maximal effective concentration: 170 nM
Compound 4: the middle estimate sits 3.5-fold (0.55 log units) above what was measured; measured number outside the range, below it.
By their numbers in this assay, from the lowest: compounds 4, 1 and 3 (each within the scatter of the next); then compound 2.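

In this assay, among the compounds shown here, moving to 4-chlorophenyl in place of 3-chloro-4-methylphenyl on the amide-type nitrogen in a ring gives a 1.4-fold lower number from compound 1 to compound 4 (0.15 log units; within the scatter), and this is the first step that isolates a single place. It shows that the aryl group there can lose a methyl and carry its chlorine at a different ring position without any change that can be told from the scatter, so compound 1's full substitution pattern is not required to hold the number at this level. The compounds shown offer no measurement that bears on why the number holds across this change.

Both edits arrive together in this one step, so what the loss of the methyl and the new place of the chlorine each contribute stays unresolved, and they could even offset one another. Also open, on these data alone, is how far this tolerance extends, for instance whether a methoxy group or a nitrile in place of the chlorine of 4-chlorophenyl, or a plain phenyl with no chlorine at all, would keep the number at the level of compound 4.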